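Swapping a methyl for a fluoro on a shared core

A few compounds are considered here, and "the series" means these few. Any claim that something is new, unique, unknown or untested is made for them only; others in the source may bear on it.

Of the compounds shown here, two of one family have been tested in a functional assay on C6 cells (Rattus norvegicus) for cytotoxicity, read by MTT assay, with a stated time of 24 h, tested at 50 ug/mL; a higher number here means a weaker effect of the compound at the concentration tested, a lower number a stronger effect. Compound 1 `Cc1nnc(SCC(=O)N/N=c2/scc(-c3ccc(F)cc3)n2-c2ccccc2)s1` gives 37.4%. Compound 2 `Cc1ccc(-c2cs/c(=N/NC(=O)CSc3nnnn3-c3ccccc3)n2-c2ccccc2)cc1` gives 29.5% in this assay, a gap to compound 1 that lies within the usual scatter of repeated measurements, so the two numbers cannot be told apart. Compound 3 `O=C(CSc1nnnn1-c1ccccc1)N/N=c1/scc(-c2ccc(F)cc2)n1-c1ccccc1` has not yet been measured. It differs from compound 2 in one place: fluoro in place of methyl on an aromatic carbon. Among the compounds with values here, no step between two measured compounds isolates this single change, so nothing here says how large an effect it should have. The two measured numbers themselves sit within the scatter of each other. The expectation for the step from compound 2 to compound 3 in this assay is therefore no change beyond the scatter: a number 3.5 percentage points higher from compound 2 to compound 3 (within the scatter). Compound 3 is estimated to give 33% in this assay, with an expected range from 20% to 48%.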

Compound 3, a percentage reported as activity, at one concentration (the size of the read-out at that concentration, not a potency): 43.7%
Compound 3: the middle estimate sits 10.7 percentage points below what was measured; the measured number falls inside the stated range.
By their numbers in this assay, from the lowest: compounds 2, 1 and 3 (each within the scatter of the next, the first and the last beyond it).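

In this assay, the change from 4-methylphenyl to 4-fluorophenyl now has a direct reading: fluoro in place of methyl on the aromatic carbon gives a modest step beyond the scatter (a number 14.2 percentage points higher from compound 2 to compound 3 (beyond the scatter)), so the fluoro compound has the weaker effect at the concentration tested. At the sulfur, the step with 1-phenyl-1H-tetrazol-5-yl in place of 5-methyl-1,3,4-thiadiazol-2-yl stays within the scatter (a number 6.3 percentage points higher from compound 1 to compound 3 (within the scatter)), so this exchange shows no detectable change with the 4-fluorophenyl group in place. Nothing available explains why the fluoro for methyl swap gives this step.

On these data alone, whether the step from methyl to fluoro holds with 5-methyl-1,3,4-thiadiazol-2-yl on the sulfur remains open. Also open, as far as these compounds go, is where a 4-chlorophenyl group, a 4-methoxyphenyl group or a plain phenyl would fall at this position.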